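A few compounds are considered here, and "the series" means these few. Any claim that something is new, unique, unknown or untested is made for them only; others in the source may bear on it.

For the measured compounds named here, in an ADME assay on Huh-7 cells (Homo sapiens) for cytotoxicity, with a stated time of 72 h (a lower number here means that less compound is tolerated, a higher number that more compound is tolerated), no compound yet has an exact number, only limits. Compound 1 `CC(C)CCn1nc(-c2cccs2)c(O)c(C2=NS(=O)(=O)c3cc(NS(=O)(=O)C4CC4)ccc3N2)c1=O` gives > 1000 nM, which is a limit. Compound 2 `CC(C)CCc1nn(CCC(C)C)c(=O)c(C2=NS(=O)(=O)c3cc(NS(C)(=O)=O)ccc3N2)c1O` gives > 33000 nM, also a limit. As far as these compounds go, compound 3 `CCC(C)(C)Cn1nc(-c2cccs2)c(O)c(C2=NS(=O)(=O)c3cc(NS(C)(=O)=O)ccc3N2)c1=O` gives > 1000 nM, again a limit, so its true position is unknown. Compound 4 `COC(C)(C)CCn1nc(-c2cccs2)c(O)c(C2=NS(=O)(=O)c3cc(NS(C)(=O)=O)ccc3N2)c1=O` carries 2-methoxy-2-methylpropyl in place of 1,1-dimethylpropyl on a saturated chain carbon bound to an aromatic nitrogen. Going by the values given here, no measured step covers this change, so the expectation rests on the limits alone, and another limit is the likeliest report. The expected step is a step that the limit leaves unreadable from compound 3 to compound 4, upward and only loosely estimated. For compound 4 the estimate is 5000 nM, with an expected range of 1000 nM to 33000 nM.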

Compound 4, half-maximal cytotoxic concentration: > 33000 nM
Compound 4: a limit, no number; the forecaster's own chance of this, stated with the estimate: 85%; at least 6.6-fold (0.81 log units) between middle value and limit.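

For the compounds shown here, compound 3 and compound 4 both give only limits, not numbers, so no step between them can be read. The compounds shown leave open whether 2-methoxy-2-methylpropyl in place of 1,1-dimethylpropyl shifts tolerance at all, since none has an exact value.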